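A Fluorophenyl Group Replaces the Hydroxypropyl Chain

The source may report more compounds than this note shows. Statements on the series, on what has been measured and on what is new or still open speak of the compounds shown alone.

Three compounds share one core and differ only in the group carried on the five-membered aromatic ring with three nitrogens. Compound 1 `CCCCc1cn(C(c2ccccc2)c2cc3cc(Br)ccc3nc2OC)nn1` carries a butyl chain and gives 5.46% in an ADME assay on PANC-1 cells (Homo sapiens) for cytotoxicity, read by sulforhodamine B assay, with a stated time of 48 h, tested at 10 uM; a higher number here means more inhibition at the concentration tested (going by the name of the read-out), a lower number less inhibition. Compound 2 `COc1nc2ccc(Br)cc2cc1C(c1ccccc1)n1cc(CCCCCO)nn1` carries a hydroxypentyl chain and gives 19.6% in this assay. Compound 3 `COc1nc2ccc(Br)cc2cc1C(c1ccccc1)n1cc(CCCO)nn1` carries a 3-hydroxypropyl chain and gives 25.5% in this assay, the highest of the three numbers, though its gap to compound 2 lies within the scatter; only its gap to compound 1 is beyond it.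

The measured steps were a number 14.1 percentage points higher from compound 1 to compound 2 (beyond the scatter), a number 20 percentage points higher from compound 1 to compound 3 (beyond the scatter) and a number 5.9 percentage points higher from compound 2 to compound 3 (within the scatter). Both chains bearing a hydroxy group thus sit modestly above the plain butyl chain, while the two hydroxy-bearing chains do not separate from each other.

Compound 4 `COc1nc2ccc(Br)cc2cc1C(c1ccccc1)n1cc(-c2ccc(F)cc2)nn1` is made from compound 3 by 4-fluorophenyl in place of 3-hydroxypropyl on an aromatic carbon. Among the compounds with values here, no measured step covers an aromatic group at this position. The only guide is that removing the hydroxy group in compound 1 gave a lower number, as shown by a number 20 percentage points higher from compound 1 to compound 3 (beyond the scatter), so compound 4 is expected to fall back toward compound 1, with an estimated step of a number 13.5 percentage points lower from compound 3 to compound 4 (beyond the scatter). Compound 4 is therefore estimated at 12%, within a range from 0% to 35%.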

Compound 4, a percentage reported as inhibition, at one concentration (the size of the read-out at that concentration, not a potency): 14.9%
Estimate against measurement, compound 4: 2.9 percentage points below; low and high end bracket the measured number.
By their numbers in this assay, from the lowest: compounds 1, 4, 2 and 3 (each within the scatter of the next, the first and the last beyond it).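

In this assay, 4-fluorophenyl in place of 3-hydroxypropyl gives a number 10.6 percentage points lower from compound 3 to compound 4 (beyond the scatter) at this aromatic carbon, so the only ring group shown here separates from the 3-hydroxypropyl chain. The same group gives a number 4.7 percentage points lower from compound 2 to compound 4 (within the scatter) when set against the 5-hydroxypentyl chain and a number 9.4 percentage points higher from compound 1 to compound 4 (within the scatter) when set against the butyl chain, so it separates from neither of them. The earlier compounds shown here, all with saturated chains, could be read as a simple divide between hydroxy-bearing chains and the butyl chain, but compound 4 carries no hydroxy group and still lies within the scatter of both compound 1 and compound 2, so that divide does not hold for it. Nothing among the data shown accounts for these differences.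

As far as these compounds go, whether the fluorine matters stays open, since a plain phenyl group or a chlorophenyl group at this carbon would be the direct comparison for compound 4. Also open, from the compounds shown here alone, is how an amine or a carboxylic acid at the end of the propyl chain would compare with the hydroxy group of compound 3.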